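Lengthening the acid chain back from compound 3

This account rests on a few compounds, and the source may have more. Where it says the series, first, only, none or still open, it means among the compounds named here.

Measured so far:
compound 1 `CCCCC[C@@H](O)/C=C/C1CCC(=O)[C@@H]1CCCCSCC(=O)O` gives 0.0113 mg/kg
compound 2 `CCCCC[C@](C)(O)/C=C/C1CCC(=O)[C@@H]1CCCCSCC(=O)O` gives 0.00185 mg/kg
compound 3 `CCCCC[C@](C)(O)/C=C/C1CCC(=O)[C@@H]1CCCSCC(=O)O` gives 2.99 mg/kg

These three compounds were tested in a functional assay on the whole organism (strain Hartley) for inhibition, with Cavia porcellus as the target, with stated times of 2 min and 15 min; a higher number here means that more compound is needed for the effect, a lower number that less compound is needed. Compound 3 stands highest of the three, needing far more compound than compound 1 or compound 2. Compound 4 `CCCCC[C@](C)(O)/C=C/C1CCC(=O)[C@@H]1CCCCCCC(=O)O` is the next compound, and its change from compound 3 is 3-carboxypropyl in place of (carboxymethyl)sulfanyl on a saturated chain carbon, three bonds along the chain from a saturated ring carbon. The step that bears on this is a 1600-fold higher number from compound 2 to compound 3 (3.21 log units; beyond the scatter), where removing one link from the chain that carries the acid made the number very much larger. Compound 4 puts a link back, with carbon in place of sulfur, so the chain to the acid is as long as in compound 2. The step from compound 1 to compound 2 is untouched here, as the methyl group stays. A large drop in the number is therefore expected, a 600-fold lower number from compound 3 to compound 4 (2.78 log units; beyond the scatter), bringing compound 4 near compound 2. Compound 4 is estimated at 0.005 mg/kg, with a range from 0.001 mg/kg to 0.03 mg/kg.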

Compound 4, dose for half-maximal effect: 0.00424 mg/kg
For compound 4 the middle estimate is 1.2-fold (0.07 log units) above the measured one; the measured number falls inside the stated range.
By their numbers in this assay, from the lowest: compound 2; then compound 4; then compound 1; then compound 3.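

Compound 4 shows that the sulfur is not needed to recover the lost effect, since an all-carbon chain of the restored length gives a 710-fold lower number from compound 3 to compound 4 (2.85 log units; beyond the scatter). In this assay, replacing the sulfur with carbon at that same chain length has a real but far smaller effect, a 2.3-fold higher number from compound 2 to compound 4 (0.36 log units; beyond the scatter). At this position, then, the large change accompanies the length of the chain to the acid, while the swap of sulfur for carbon counts for much less in these compounds.

An oxygen in place of the sulfur, a longer chain, or an all-carbon chain as short as that of compound 3 would show how far this holds. No measurement here explains why chain length matters so strongly.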